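The source may hold more compounds than are shown below. What is called first, only, known or untested is meant among the compounds shown, and "the series" means these compounds.

Working notes on the series. Going by the values given here, in a functional assay on A549 cells (Homo sapiens) for cytotoxicity, read by MTT assay (on this read-out higher numbers stand for weaker inhibition and lower numbers for stronger inhibition), compound 1 (`COC(=O)C[C@H]1C[C@H](O)[C@@H](C)[C@@H](c2ccc(C)cc2)N1`) gives 97600 nM, the only number so far. Compound 2 (`COC(=O)C[C@H]1C[C@@H](O)[C@@H](C)[C@@H](c2ccc(C(C)C)cc2)N1`) is reported as "not active" (no number reported), so it has no single number and its position can be stated only in those words. The next compound is compound 3 (`COC(=O)C[C@H]1C[C@H](O)[C@@H](C)[C@@H](c2ccc(C(C)C)cc2)N1`). The change is the two compounds have the same atoms and bonds and differ only in configuration as drawn: 1 of 4 stereo elements differ; a stereocentre at a saturated ring carbon is drawn R in compound 2 and S in compound 3: a stereocentre at a saturated ring carbon is drawn R before the step and S after it. Among the compounds with values here, no measured step shows what such an inversion does in this assay. The expected change is small: at best a move from no number to a weak reading, toward lower numbers, and possibly none at all. Within the data shown here, this expectation rests on compound 1 at 97600 nM, the only reading available, and a second report without a number remains quite possible. For compound 3 the estimated value is 100000 nM, with an expected range of 40000 nM to 250000 nM.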

Compound 3, half-maximal inhibitory concentration: "not active" (no number reported)
Nothing numeric was reported for compound 3; there is nothing to compare the estimate with.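

Compound 2 and compound 3 are both reported without a number in this assay, so no step can be read between them: the fact that compounds 2 and 3 differ only in the configuration as drawn

What the compounds shown leave open is whether the inversion at this saturated ring carbon changes anything in this read-out.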